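Replacing the ring-bearing group on the carbonyl of compound 3

This account rests on a few compounds, and the source may have more. Where it says the series, first, only, none or still open, it means among the compounds named here.

Values in a functional assay on PC-3 cells (Homo sapiens) for antiproliferative activity, read by MTT assay, with a stated time of 72 h (on this read-out higher numbers stand for weaker inhibition and lower numbers for stronger inhibition), so far:
- compound 1 `CCN(CC)CCNC(=O)c1ccc(C(CC)(CC)c2ccc(OCC(O)C(C)(C)C)c(C)c2)n1CC` gives 2800 nM
- compound 2 `CCN(CC)CCCNC(=O)c1ccc(C(CC)(CC)c2ccc(C#CC(O)(CC)CC)c(C)c2)n1CC` gives 8500 nM
- compound 3 `CCn1c(C(=O)On2nnc3ccccc32)ccc1C(CC)(CC)c1ccc(C#CC(O)(CC)CC)c(C)c1` gives > 50000 nM as a limit of the assay

Compound 3 yields no number in this assay and stands only at a limit (the limit of > 50000 nM in this assay, at which 1 of the 3 values shown sits). Compound 4 `CCn1c(C(=O)NCCC(=O)O)ccc1C(CC)(CC)c1ccc(C#CC(O)(CC)CC)c(C)c1` differs from compound 3 as follows: a group of 6 heavy atoms (3 carbon, 1 nitrogen, 2 oxygen; no ring) in place of a group of 10 heavy atoms (6 carbon, 3 nitrogen, 1 oxygen; one five-membered aromatic ring with 3 hetero atoms, one six-membered aromatic ring of carbon only), on a carbonyl carbon (the entering group is (2-carboxyethyl)amino).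

Within the data shown here, the one measured step at this carbonyl carbon is an at least 5.8-fold higher number from compound 2 to compound 3 (0.76 log units; beyond the scatter) and it ends at the limit, so its true size remains open. Read backwards, that step suggests that losing the ring-bearing group could bring the series back into the measurable range. Among the measured compounds shown here, the entering group is not the one carried by compound 2, so a full return to the 8500 nM of that compound is not assumed. For the measured compounds named here, no measured compound carries the (2-carboxyethyl)amino group, and compound 4 may well remain at the limit.

The expected change is an at least 2.5-fold lower number from compound 3 to compound 4 (0.39 log units; beyond the scatter) in this assay and it points towards a lower number, with its size poorly fixed. For compound 4 the estimated value is 20000 nM within an expected range (6000 nM to 50000 nM).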

Compound 4, half-maximal inhibitory concentration: 5130 nM
Estimate against measurement, compound 4: 3.9-fold (0.59 log units) above; measured number outside the range, below it.
By their numbers in this assay, from the lowest: compounds 1, 4 and 2 (each within the scatter of the next, the first and the last beyond it). At a limit, above all of these: compound 3.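

In this assay, on these data alone, (2-carboxyethyl)amino in place of the ring-bearing group on the carbonyl carbon gives an at least 9.7-fold lower number from compound 3 to compound 4 (0.98 log units; beyond the scatter), which brings the series back into the measurable range, though the true size of this step remains open. Compound 3 has a limit and not a number: the limit of > 50000 nM in this assay, at which 1 of the 4 values shown sits.

At the end of the amide chain, carboxy in place of (diethylamino)methyl on a saturated chain carbon gives a 1.7-fold lower number from compound 2 to compound 4 (0.22 log units; within the scatter), so at this place the compounds carrying these two chain ends cannot be told apart in this assay, even though the two groups are quite different by name.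

As far as these compounds go, with only these two chain ends in hand, it remains open whether the end of the chain matters at all here, and a methyl ester in place of the carboxylic acid, or a longer chain ending in the same acid, would test that. A simple ethylamide on the carbonyl carbon would show whether the amide alone, with neither an amine nor a carboxylic acid on its chain, is enough to keep a measurable value.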